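Pyridin-3-yl Enters Where Three Aryl Groups Gave Nothing

The source may report more compounds than this note shows. Statements on the series, on what has been measured and on what is new or still open speak of the compounds shown alone.

In an assay on CHO cells for displacement of a labelled ligand from adenosine receptor A3 (Homo sapiens), read by scintillation counting, with a stated time of 120 min, tested at 10 uM (a higher number here means more inhibition at the concentration tested (going by the name of the read-out), a lower number less inhibition), three compounds have been measured:

compound 1 `Nc1scc(CN2CCN(c3ccc(Cl)cc3F)CC2)c1C(=O)c1ccc(Cl)cc1` gives 1%
compound 2 `COc1ccc(N2CCN(Cc3csc(N)c3C(=O)c3ccc(Cl)cc3)CC2)cc1` gives 0%
compound 3 `Nc1scc(CN2CCN(c3ccc([N+](=O)[O-])cc3)CC2)c1C(=O)c1ccc(Cl)cc1` gives 2%

All three share one core and differ only in the group on an amine nitrogen in a ring. Compound 3 stands beside the other two rather than apart from them: the step of a number 1 percentage points higher from compound 1 to compound 3 (within the scatter) and the step of a number 2 percentage points higher from compound 2 to compound 3 (within the scatter) are both within the scatter, as is a number 1 percentage points lower from compound 1 to compound 2 (within the scatter), so the three numbers cannot be ranked against each other.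

Compound 4 `Nc1scc(CN2CCN(c3cccnc3)CC2)c1C(=O)c1ccc(Cl)cc1` is the next member of the set. It differs from compound 3 in the same place where the others differ: pyridin-3-yl in place of 4-nitrophenyl on an amine nitrogen in a ring. The two measured steps that bear on this change, a number 1 percentage points higher from compound 1 to compound 3 (within the scatter) and a number 2 percentage points higher from compound 2 to compound 3 (within the scatter), swap groups on that same ring nitrogen and produce nothing beyond the scatter. On that basis no step beyond the scatter is expected in this assay for compound 4 either, in neither direction, and the change estimated is no change at the digits printed from compound 3 to compound 4 (within the scatter). Compound 4 is therefore expected to give about 2% in this assay, within a range from -5% to 10%.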

Compound 4, a percentage reported as inhibition, at one concentration (the size of the read-out at that concentration, not a potency): 0%
Compound 4: middle estimate off by 2 percentage points, on the high side; the range from low to high includes it.
By their numbers in this assay, from the lowest: compounds 2, 4, 1 and 3 (each within the scatter of the next).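

With pyridin-3-yl on the ring nitrogen, this assay gives these readings: a number 2 percentage points lower from compound 3 to compound 4 (within the scatter) and no change at the digits printed from compound 2 to compound 4 (within the scatter) and a number 1 percentage points lower from compound 1 to compound 4 (within the scatter). The earlier compounds shown here had varied this position only among phenyl rings carrying substituents, so compound 4 adds something new: a six-membered aromatic ring with one hetero atom, and a smaller group, with 6 heavy atoms where 4-nitrophenyl has 9, still leaves all four compounds within the scatter of one another, and none of the four goes against this. Since every reading comes from a single concentration and sits close to zero, the set records the absence of any measurable separation at this position and gives no ranking of the four groups, and nothing measured here offers an explanation for that flat result.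

On these data alone, what remains open is whether any group on this ring nitrogen can lift the reading at all, such as a benzyl group, an acetyl group or a short chain ending in a carboxylic acid. Also open, as far as these compounds go, is whether a change elsewhere on the shared core, for example replacing the chlorine on the 4-chlorophenyl ketone with a methoxy group, would move the number in this assay when these same aryl groups are kept.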